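Chain lengthening on the amine side of the shared core

The source may hold more compounds than are shown below. What is called first, only, known or untested is meant among the compounds shown, and "the series" means these compounds.

Three measured compounds share one core and differ only in the ether substituent: compound 1 `CN(C)CCNc1ccnc2cc(OCc3ccccc3)ccc12`, compound 2 `C=CCOc1ccc2c(NCCN(C)C)ccnc2c1` and compound 3 `CCOc1ccc2c(NCCN(C)C)ccnc2c1`. In a functional assay on DLD-1 cells (Homo sapiens) for cytotoxicity, read by MTT assay, with a stated time of 48 h (a lower number here means a stronger inhibitor, a higher number a weaker inhibitor), compound 1 gives 2140 nM, compound 2 gives 1530 nM and compound 3 gives 6240 nM. Compound 2 has the lowest of the three numbers; compound 1 sits within the scatter of it, while compound 3 lies beyond. The measured steps all concern the ether substituent: a 1.4-fold lower number from compound 1 to compound 2 (0.15 log units; within the scatter), a 2.9-fold higher number from compound 1 to compound 3 (0.46 log units; beyond the scatter) and a 4.1-fold higher number from compound 2 to compound 3 (0.61 log units; beyond the scatter).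

Compound 4 `C=CCOc1ccc2c(NCCCN(C)C)ccnc2c1` keeps the ether of compound 2 and alters the amine side: (dimethylamino)methyl in place of dimethylamino on a saturated chain carbon, two bonds along the chain from a nitrogen on an aromatic ring. Among the measured compounds shown here, none of the measured steps touches this part of the molecule, and none bears on the change; the ether comparisons show only that the series moves within a modest spread. For the measured compounds named here, with no bearing step available, the step of a 1.0-fold lower number from compound 2 to compound 4 (0.01 log units; within the scatter) is expected to stay within the scatter. Compound 4 is estimated at 1500 nM in this assay, with a range from 600 nM to 4000 nM that is kept wide for an untested change.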

Compound 4, half-maximal inhibitory concentration: 5180 nM
Compound 4: middle estimate off by 3.5-fold (0.54 log units), on the low side; the measured number lies above the stated range.
By their numbers in this assay, from the lowest: compounds 2 and 1 (each within the scatter of the next); then compounds 4 and 3 (each within the scatter of the next).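

Working notes on the amine side: in this assay, changing (2-(dimethylamino)ethyl)amino to (3-(dimethylamino)propyl)amino while the ether stays fixed gives a 3.4-fold higher number from compound 2 to compound 4 (0.53 log units; beyond the scatter), so this position responds to chain length. Among the compounds shown here, the earlier steps all concerned the ether and said nothing about this part of the molecule; this pair is the first reading here, and in it the 2-(dimethylamino)ethyl chain carries the lower number and the 3-(dimethylamino)propyl chain the higher one, a direction resting on this single pair alone. Nothing available bears on why the number rises with this change.

Among the compounds shown, the amine side is compared on the ether of compound 2 only, so whether the same change moves the number in the same way on the ethers of compound 1 and compound 3 remains open. Also open, as far as these compounds go, is how the series responds to a longer chain such as 4-(dimethylamino)butyl, or to a different amine at the chain end, such as diethylamino or a morpholine ring.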